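The source may report more compounds than this note shows. Statements on the series, on what has been measured and on what is new or still open speak of the compounds shown alone.

Measured so far:
compound 1 `COc1cc(C(C)=O)ccc1OCCCN1CCC(C(NC(C)=O)(c2ccc(F)cc2)c2ccc(F)cc2)CC1`: 63.1 nM
compound 2 `COC(=O)c1ccc(OCCCN2CCC(C(c3ccc(F)cc3)c3ccc(F)cc3)CC2)c(OC)c1`: 1.26 nM

Both numbers come from a functional assay (aorta) with Oryctolagus cuniculus as the target; on this read-out higher numbers stand for weaker binding and lower numbers for tighter binding. Among the measured compounds shown here, compound 2 stands lowest of the two; its only neighbour, compound 1, gives a number far above it, a gap beyond the usual scatter.

Compound 3 `CC(C)(C)c1ccc(OCCCN2CCC(C(c3ccc(F)cc3)c3ccc(F)cc3)CC2)cc1` is not yet measured. Relative to compound 2 it carries 4-(tert-butyl)phenyl in place of 2-methoxy-4-(methoxycarbonyl)phenyl on an oxygen on a saturated carbon. For the measured compounds named here, no measured pair shows this change, so its size rests on expectation alone. The step of a 4.8-fold higher number from compound 2 to compound 3 (0.68 log units; beyond the scatter) is expected to be moderate and toward weaker binding in this assay. Compound 3 is estimated at 6 nM, with a range from 1.5 nM to 25 nM.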

Compound 3, dissociation constant: 1 nM
Beside the measured number, compound 3's estimate is 6.0-fold (0.78 log units) above it, and the stated range ends above it.
By their numbers in this assay, from the lowest: compounds 3 and 2 (each within the scatter of the next); then compound 1.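

In this assay the change to 4-(tert-butyl)phenyl on an oxygen on a saturated carbon gives a 1.3-fold lower number from compound 2 to compound 3 (0.10 log units; within the scatter) and so leaves the read-out within the scatter. The 3 hydrogen-bond acceptors of the departing 2-methoxy-4-(methoxycarbonyl)phenyl can therefore be absent at this position without a loss beyond the scatter. No measurement shown here accounts for this tolerance. Still open, going by these compounds, is whether a carboxylic acid or an amine in place of the tert-butyl group would keep the number within the scatter. A longer chain on that oxygen also remains untested in the compounds shown.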